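The source may hold more compounds than are shown below. What is called first, only, known or untested is meant among the compounds shown, and "the series" means these compounds.

In an ADME assay on J774.A1 cells (Mus musculus) for cytotoxicity, read by MTT assay, with a stated time of 48 h (on this read-out lower numbers stand for higher toxicity in this test and higher numbers for lower toxicity in this test), compound 1 (`COc1ccc(CNC(=O)c2c([N+](=O)[O-])noc2-c2ccc(Cl)cc2)cc1`) gives 89500 nM. Compound 2 (`COC(=O)c1c(NCCCCNc2ccnc3cc(Cl)ccc23)noc1-c1ccccc1[N+](=O)[O-]`) gives 77700 nM, and these two numbers lie within the usual scatter of each other. Compound 3 (`COC(=O)c1c(NCCCCNc2ccnc3cc(Cl)ccc23)noc1-c1ccc(Cl)cc1Cl`) carries 2,4-dichlorophenyl in place of the 2-nitrophenyl of compound 2 on an aromatic carbon: 2,4-dichlorophenyl in place of 2-nitrophenyl on an aromatic carbon. For the measured compounds named here, no pair of measured compounds isolates this exchange, so the data offer no direct guide to its size. In this assay, the expected 1.4-fold lower number from compound 2 to compound 3 (0.15 log units; within the scatter) is a small one toward a lower number, not beyond the scatter. For compound 3, the estimated value is 55000 nM, with an expected range of 22000 nM to 120000 nM.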

Compound 3, half-maximal cytotoxic concentration: 93600 nM
Compound 3: middle estimate off by 1.7-fold (0.23 log units), on the low side; the measured number falls inside the stated range.
By their numbers in this assay, from the lowest: compounds 2, 1 and 3 (each within the scatter of the next).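

In this assay, for the compounds shown here, the exchange of 2-nitrophenyl for 2,4-dichlorophenyl, on the aromatic carbon next to the ring oxygen, gives a 1.2-fold higher number from compound 2 to compound 3 (0.08 log units; within the scatter) and so provides the first direct reading of a change at this position. Across this one exchange, the read-out does not move beyond the scatter. The data offer nothing that bears on the reason for this result.

As far as these compounds go, it remains open how a phenyl ring carrying an amine or a carboxylic acid would read at this position. From the compounds shown here alone, it is also open whether a pyridine ring would stay within the scatter of compound 2.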